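Series notes: trifluoromethyl on the aryl arm of compound 2

The source may report more compounds than this note shows. Statements on the series, on what has been measured and on what is new or still open speak of the compounds shown alone.

Three members of the series have been run through a functional assay on EKVX cells (Homo sapiens) for inhibition, read by sulforhodamine B assay, with a stated time of 48 h, tested at 10 uM; on this read-out higher numbers stand for more inhibition at the one concentration tested (going by the name of the read-out) and lower numbers for less inhibition. Compound 1 `Brc1cn2ccnc2c(-c2ccc3ncn(C4CCCCC4)c3c2)n1` carries bromo on the core and gives 12%. Compound 2 `c1ccc(-c2cn3ccnc3c(-c3ccc4ncn(C5CCCCC5)c4c3)n2)cc1` carries phenyl in its place and gives 24.2%; compound 3 `COc1ccccc1-c1cn2ccnc2c(-c2ccc3ncn(C4CCCCC4)c3c2)n1` carries 2-methoxyphenyl and gives 13.4%. Among these three, compound 2 stands highest, its nearest neighbour being compound 3 and the furthest compound 1. The steps read a number 12.2 percentage points higher from compound 1 to compound 2 (beyond the scatter), a number 1.4 percentage points higher from compound 1 to compound 3 (within the scatter) and a number 10.8 percentage points lower from compound 2 to compound 3 (beyond the scatter).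

Compound 4 `FC(F)(F)c1cccc(-c2cn3ccnc3c(-c3ccc4ncn(C5CCCCC5)c4c3)n2)c1` is not yet measured. It differs from compound 2 by trifluoromethyl in place of hydrogen on an aromatic carbon. Going by the values given here, the only measured step that touches the phenyl arm itself is the one from compound 2 to compound 3, where a methoxy added to the ring cost a modest amount beyond the scatter. That is a single observation with a different group at a different ring carbon, so it carries limited weight for the present change. On this basis a small loss, or no step beyond the scatter, is expected in this assay: a number 6.2 percentage points lower from compound 2 to compound 4 (within the scatter) for compound 4. The estimate for compound 4 is 18%, with a range from 5% to 32%.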

Compound 4, a percentage reported as inhibition, at one concentration (the size of the read-out at that concentration, not a potency): 4.79%
Estimate against measurement, compound 4: 13.2 percentage points above, outside the stated range (below it).
By their numbers in this assay, from the lowest: compounds 4, 1 and 3 (each within the scatter of the next); then compound 2.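

In this assay the step of a number 19.4 percentage points lower from compound 2 to compound 4 (beyond the scatter) shows that trifluoromethyl on this ring carbon, meta to a large group, also takes the read-out down from the plain phenyl, so the loss seen with the methoxy of compound 3 is no longer a lone case. Going by these compounds alone, the substituted arm of compound 4 also stands apart from neither of the other two, with a number 8.6 percentage points lower from compound 3 to compound 4 (within the scatter) and a number 7.2 percentage points lower from compound 1 to compound 4 (within the scatter) as the steps, which leaves the unsubstituted phenyl of compound 2 as the only one of the four compounds separated from the rest by more than the scatter. Nothing at hand bears on why substitution on this ring goes with the loss.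

The methoxy of compound 3 and the trifluoromethyl of compound 4 differ both in the group and in the ring carbon that carries it, so the effect of the group and that of its place on the ring remain unseparated. On these data alone, whether an amine or a carboxylic acid on the phenyl arm would hold the level of compound 2 in this assay remains open, as does whether any group on this ring can do so.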